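A few compounds are considered here, and "the series" means these few. Any claim that something is new, unique, unknown or untested is made for them only; others in the source may bear on it.

Compounds measured so far: compound 1 `ClCc1ccccc1Cn1cnc2c(Cl)nc(Cl)nc21` with 5120 nM; compound 2 `ClCc1cccc(Cn2cnc3c(Cl)nc(Cl)nc32)c1` with 55000 nM; compound 3 `Nc1nc(Cl)c2ncn(Cc3ccccc3CCl)c2n1`. The value of compound 3 is given below as a limit of the assay.

In a functional assay on PC-3 cells (Homo sapiens) for cytotoxicity, read by sulforhodamine B assay, with a stated time of 48 h (a higher number here means that more compound is tolerated, a lower number that less compound is tolerated), compound 1 gives 5120 nM. Compound 2 gives 55000 nM, the higher of the two numbers; how the core of compound 2 differs from that of compound 1 is not broken down here. Compound 3 reaches only a limit of the assay, > 100000 nM. The change amino in place of chloro on an aromatic carbon thus produced an at least 19-fold higher number from compound 1 to compound 3 (1.29 log units; beyond the scatter), and the value of compound 3 sits at the limit of > 100000 nM in this assay, at which 1 of the 3 values shown sits.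

Compound 4 `Nc1nc(Cl)c2ncn(Cc3cccc(CCl)c3)c2n1` is not yet measured. It differs from compound 2 by amino in place of chloro on an aromatic carbon, the same change as that from compound 1 to compound 3, at a place described in the same words. The step is expected to be a 5.5-fold higher number from compound 2 to compound 4 (0.74 log units; beyond the scatter), resting on the step from compound 1 to compound 3 an at least 19-fold higher number from compound 1 to compound 3 (1.29 log units; beyond the scatter) applied to compound 2 55000 nM. Compound 4 is therefore estimated at 300000 nM, most likely reported only as a limit.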

Compound 4, concentration lethal to 50% of the cells: 63100 nM
For compound 4 the middle estimate is 4.8-fold (0.68 log units) above the measured one; measured number below the stated range.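

In this assay, amino in place of chloro on an aromatic carbon gives a 1.1-fold higher number from compound 2 to compound 4 (0.06 log units; within the scatter), so the large step seen on the core of compound 1 does not carry over to the core of compound 2, and the two steps differ: the same change on two cores in this assay, an at least 19-fold higher number (1.29 log units; beyond the scatter) from compound 1 to compound 3 and a 1.1-fold higher number (0.06 log units; within the scatter) from compound 2 to compound 4, at least 17-fold (1.23 log units) apart, beyond the scatter of two such steps

The value of compound 3 is a limit of the assay and not a number, which means the step on the core of compound 1 is known only as a bound: the limit of > 100000 nM in this assay, at which 1 of the 4 values shown sits.

This shows that, across these two pairs, the change cannot be moved from one core to the other as a fixed step, but with a single pair on each core it does not show why the two cores part, nor what the change would do on any further core.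

The compounds shown leave open whether a methoxy group or a dimethylamine in place of the same chloro would follow the pattern of amino on either core. They also leave open how a longer chain in place of the chloromethyl group would alter the outcome of this change.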